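Replacing the thiophene acyl group with a succinyl acid chain

The source may hold more compounds than are shown below. What is called first, only, known or untested is meant among the compounds shown, and "the series" means these compounds.

The series rests on a shared core, shown in compound 1 `CCOC(=O)C1=C(C)NC(C)=C(C(=O)OCC)C1c1ccc(OCC(=O)NNC(=O)c2sccc2Cl)cc1` and compound 2 `CCOC(=O)C1=C(C)NC(C)=C(C(=O)OCC)C1c1ccc(OCC(=O)NNC(=O)c2cccs2)cc1`. In a functional assay on the whole organism (strain Wistar) for inhibition, with Rattus norvegicus as the target, read by paw edema, with stated times of 30 min and 2 h, at a dose of 20 mg/kg (a lower number here means less inhibition, a higher number more inhibition at the dose given (going by the name of the read-out)), compound 1 gives 57.2%, and compound 2 gives 62.2%. Among the measured compounds shown here, the one measured step, a number 5 percentage points higher from compound 1 to compound 2 (within the scatter), arises from hydrogen in place of chloro on an aromatic carbon, so the two numbers stand within the scatter of each other and compound 2 cannot be set apart from compound 1 on these data.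

Compound 3 `CCOC(=O)C1=C(C)NC(C)=C(C(=O)OCC)C1c1ccc(OCC(=O)NNC(=O)CCC(=O)O)cc1` differs from compound 2 by 2-carboxyethyl in place of thiophen-2-yl on a carbonyl carbon. For the measured compounds named here, no measured step touches this part of the molecule, and the single step available did not move the read-out beyond the scatter. Compound 3 is therefore expected to stay near compound 2, with a number 7.2 percentage points lower from compound 2 to compound 3 (within the scatter) as the estimated step. Compound 3 is estimated at 55%, within a range of 40% to 68%.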

Compound 3, a percentage reported as inhibition, in the whole organism at one dose (the size of the read-out at that dose, not a potency): 57.8%
For compound 3 the middle estimate is 2.8 percentage points below the measured one, within the range that was stated.
By their numbers in this assay, from the lowest: compounds 1, 3 and 2 (each within the scatter of the next).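

In this assay, placing 2-carboxyethyl on the carbonyl carbon gives a number 4.4 percentage points lower from compound 2 to compound 3 (within the scatter), and the same exchange starting from 3-chlorothiophen-2-yl gives a number 0.6 percentage points higher from compound 1 to compound 3 (within the scatter). The earlier pair varied only a substituent on the thiophene, whereas these steps remove the five-membered aromatic ring altogether and put an open chain with no ring in its place, and the read-out of compound 3 cannot be told apart from those of compound 1 and compound 2. Nothing available here accounts for this outcome.

Going by these compounds, whether an amine or a methyl ester at the end of the chain, or a longer chain, would read any differently at this position remains open. So does whether a six-membered phenyl ring on the same carbonyl carbon would stay within this group of three compounds.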